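Dropping the triazole methyl from compound 1

The source may hold more compounds than are shown below. What is called first, only, known or untested is meant among the compounds shown, and "the series" means these compounds.

Among the compounds with values here, in an in vitro ADME assay on microsomes from liver (Homo sapiens) for metabolic stability (a lower number here means slower removal, a higher number faster removal of the compound), compound 1 `Cc1n[nH]c(-c2nc(Cc3ccccc3F)c3ccccn23)n1` gives 124 mL.min-1.g-1, the only exact number so far. Compound 2 `Fc1ncncc1Cn1nc(-c2nc(C(F)(F)F)n[nH]2)c2cccnc21` is reported only as a limit, < 11 mL.min-1.g-1. Compound 3 `Fc1ccccc1Cc1nc(-c2ncn[nH]2)n2ccccc12` keeps the rest of compound 1 but turns 3-methyl-1H-1,2,4-triazol-5-yl into 1H-1,2,4-triazol-5-yl, with hydrogen in place of methyl on an aromatic carbon. Within the data shown here, no measured pair isolates this change. The expected result is a 1.2-fold lower number from compound 1 to compound 3 (0.09 log units; within the scatter), a small fall within the scatter of this assay. For compound 3 the estimate is 100 mL.min-1.g-1, with an expected range from 50 mL.min-1.g-1 to 190 mL.min-1.g-1.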

Compound 3, intrinsic clearance in microsomes: 175 mL.min-1.g-1
Estimate against measurement, compound 3: 1.8-fold (0.24 log units) below, and the stated range covers the measured number.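

Within the data shown here, this is the first step read at this position: in this assay, going from 3-methyl-1H-1,2,4-triazol-5-yl to 1H-1,2,4-triazol-5-yl gives a 1.4-fold higher number from compound 1 to compound 3 (0.15 log units; within the scatter). The methyl on this aromatic carbon therefore makes no difference beyond the scatter in this pair. Nothing shown bears on the reason for this step.

Going by these compounds, whether an ethyl group or an amine on this carbon would give a step beyond the scatter remains open. Compound 2 gives < 11 mL.min-1.g-1, which is a limit, and it differs from compound 1 in more than one place, so it cannot settle this position.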